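This account rests on a few compounds, and the source may have more. Where it says the series, first, only, none or still open, it means among the compounds named here.

In an assay on HeLa cells for displacement of a labelled ligand from 5-hydroxytryptamine receptor 6 (Homo sapiens) (on this read-out higher numbers stand for weaker inhibition and lower numbers for stronger inhibition), compound 1 `COc1cccc(S(=O)(=O)c2n[nH]c3ccc(N4CCN(C)CC4)cc23)c1` gives 1.1 nM, compound 3 `Cc1ccc(S(=O)(=O)c2n[nH]c3cc(N4CCNCC4)ccc23)cc1` gives 27 nM, and compound 2 `O=S(=O)(c1ccc(Cl)cc1)c1n[nH]c2cccc(N3CCNCC3)c12` gives 125 nM. Compound 2 thus stands highest of the three numbers, with compound 3 nearest and compound 1 furthest, both gaps beyond the scatter. Compound 4 `COc1ccc(S(=O)(=O)c2n[nH]c3cccc(N4CCNCC4)c23)cc1` awaits measurement in this assay. It differs from compound 2 in one place: methoxy in place of chloro on an aromatic carbon. For the measured compounds named here, no measured pair shows this change alone, so its size is uncertain. Compound 1, which carries a methoxy and gives 1.1 nM, and compound 3, which carries a methyl and gives 27 nM, also differ from compound 2 elsewhere. For compound 4 a modest step down in this assay is expected, a 2.1-fold lower number from compound 2 to compound 4 (0.32 log units; beyond the scatter). Compound 4 is estimated at 60 nM, within 15 nM to 250 nM.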

Compound 4, inhibition constant: 88 nM
Beside the measured number, compound 4's estimate is 1.5-fold (0.17 log units) below it, within the range that was stated.
By their numbers in this assay, from the lowest: compound 1; then compound 3; then compounds 4 and 2 (each within the scatter of the next).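

Chloro and methoxy on this aromatic carbon, para to a large group, can now be compared directly: in this assay the change from 4-chlorophenyl to 4-methoxyphenyl gives a 1.4-fold lower number from compound 2 to compound 4 (0.15 log units; within the scatter) and so stays within the scatter. For the compounds shown here, this is the first single-place step, and at this position it separates the two compounds by no more than repeat measurements would. Nothing available here accounts for this result. Going by these compounds, whether an amine or a carboxylic acid at this position would move the number remains open. So does whether chloro and methoxy would also stay level on the core of compound 1.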